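Swapping pyridin-4-yl for benzyl on the piperazine nitrogen

The source may report more compounds than this note shows. Statements on the series, on what has been measured and on what is new or still open speak of the compounds shown alone.

Measured compounds:
- compound 1 `Nc1ccccc1NC(=O)c1ccc(CSC(=S)N2CCN(C(c3ccccc3)c3ccccc3)CC2)cc1`: 8.7%
- compound 2 `Nc1ccccc1NC(=O)c1ccc(CSC(=S)N2CCN(Cc3ccncc3)CC2)cc1`: 33.1%
- compound 3 `Nc1ccccc1NC(=O)c1ccc(CSC(=S)N2CCN(c3ccncc3)CC2)cc1`: 85.7%

These three compounds were tested in a functional assay on A-375 cells (Homo sapiens) for antiproliferative activity, read by CCK-8 assay, with a stated time of 72 h, tested at 2 uM; on this read-out lower numbers stand for a weaker effect and higher numbers for a stronger effect at the one concentration tested. Compound 3 stands highest of the three numbers; its nearest neighbour is compound 2, and compound 1 lies furthest away, both gaps being beyond the scatter. The unmeasured compound 4 `Nc1ccccc1NC(=O)c1ccc(CSC(=S)N2CCN(Cc3ccccc3)CC2)cc1` differs from compound 3 in one place: benzyl in place of pyridin-4-yl on an amine nitrogen in a ring.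

Among the measured compounds shown here, one measured step bears on this change. Going a number 52.6 percentage points higher from compound 2 to compound 3 (beyond the scatter), so removing a single carbon between the ring nitrogen and the pyridin-4-yl group raised the number strongly. Compound 4 reintroduces such a carbon, now carrying a ring with no nitrogen, which makes it resemble compound 2 and, in the absence of a ring nitrogen, also compound 1. A large fall from compound 3 is therefore expected, and the estimated step is a number 60.7 percentage points lower from compound 3 to compound 4 (beyond the scatter). For compound 4 the expected value in this assay is 25%, with a likely range from 5% to 55%.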

Compound 4, a percentage reported as inhibition, at one concentration (the size of the read-out at that concentration, not a potency): 10.6%
The estimate for compound 4 lay 14.4 percentage points above the measured number; the range from low to high includes it.
By their numbers in this assay, from the lowest: compounds 1 and 4 (each within the scatter of the next); then compound 2; then compound 3.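

Benzyl in place of pyridin-4-yl on the amine nitrogen in a ring gives, in this assay, a number 75.1 percentage points lower from compound 3 to compound 4 (beyond the scatter), so the high number of compound 3 is lost with this change. With the saturated chain carbon kept, phenyl in place of pyridin-4-yl still gives a number 22.5 percentage points lower from compound 2 to compound 4 (beyond the scatter), a modest step that shows the ring nitrogen of pyridin-4-yl matters even with that carbon present. Hydrogen in place of phenyl on that chain carbon gives a number 1.9 percentage points higher from compound 1 to compound 4 (within the scatter), so the second phenyl of compound 1 makes no difference that can be read here.

No measurement shown gives a reason for these steps. Still open, going by these compounds, is how phenyl on that amine nitrogen, with no chain carbon, would compare with compound 3, which would separate the part played by the chain carbon from that of the ring nitrogen.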